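The compounds below may be only part of what the source reports. "The series", "measured", "known", "first", "only" and "open" are said of these compounds alone.

Of the compounds shown here, three have been tested so far in a functional assay on Caco-2 cells (Homo sapiens) for cytotoxicity, with a stated time of 48 h; a lower number here means a stronger inhibitor, a higher number a weaker inhibitor. There, compound 1 `COc1cc(O)c(C(=O)/C=C/c2ccc(F)cc2)c(OC)c1` gives 9200 nM and compound 3 `COc1cc(O)c(C(=O)/C=C/c2ccccc2OC)c(OC)c1` gives 10000 nM. Compound 2 `COc1cccc(/C=C/C(=O)c2c(OC)cc(OC)cc2OC)c1` gives 3900 nM, the lowest of the three numbers, and its distance to each of the other two lies beyond the scatter. The account now moves to compound 4 `COc1cc(OC)c(C(=O)/C=C/c2ccc(F)cc2)c(OC)c1`, which departs from compound 2 in a single place: 4-fluorophenyl in place of 3-methoxyphenyl on a double-bonded chain carbon bound to a double-bonded chain carbon. Within the data shown here, the 4-fluorophenyl group already occurs in compound 1, which gives 9200 nM, but compound 1 also differs from compound 4 elsewhere, and no measured pair isolates this change. The expectation therefore rests on compound 2 at 3900 nM, with compound 1 as a weak hint toward a higher number. The step of a 1.3-fold higher number from compound 2 to compound 4 (0.11 log units; within the scatter) is expected to be small and upward, and it is expected to stay within the scatter. Compound 4 is estimated at 5000 nM, with an expected range from 2000 nM to 12000 nM.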

Compound 4, half-maximal inhibitory concentration: 5500 nM
For compound 4 the middle estimate is 1.1-fold (0.04 log units) below the measured one; measured number inside the range.
By their numbers in this assay, from the lowest: compounds 2, 4, 1 and 3 (each within the scatter of the next, the first and the last beyond it).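

In this assay, among these compounds, 4-fluorophenyl in place of 3-methoxyphenyl on a double-bonded chain carbon bound to a double-bonded chain carbon gives a 1.4-fold higher number from compound 2 to compound 4 (0.15 log units; within the scatter), the first reading of a single change at this place, and it stays within the scatter. The new compound also isolates a second place: methyl in place of hydrogen on an oxygen on an aromatic ring gives a 1.7-fold lower number from compound 1 to compound 4 (0.22 log units; within the scatter), again within the scatter. Nothing measured here bears on the cause of either step.

Each of these changes is seen only once, on one background, so neither can be generalised. Going by these compounds, whether a carboxylic acid or an amine on a double-bonded chain carbon, or an ethyl group in place of that methyl, would reach beyond the scatter stays open.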